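This account rests on a few compounds, and the source may have more. Where it says the series, first, only, none or still open, it means among the compounds named here.

Measured so far:
compound 1, `CCNc1nc(Cl)nc(N[C@@H](C)c2ccccc2)n1`, 30900 nM in an ADME assay on the whole organism for inhibition, with Echinochloa crus-galli var. formosensis as the target, with a stated time of 4 days; a higher number here means a weaker inhibitor, a lower number a stronger inhibitor
compound 2, `CCNc1nc(Cl)nc(N[C@H](C)c2ccccc2)n1`, 2690 nM in this assay

Going by the values given here, compound 2 stands at the lowest of the two numbers, and its only neighbour is compound 1: the change recorded as an 11-fold lower number from compound 1 to compound 2 (1.06 log units; beyond the scatter) is a large one, and it rests on the fact that compounds 1 and 2 differ only in the configuration as drawn alone. Compound 3, `CC(C)Nc1nc(Cl)nc(N[C@H](C)c2ccccc2)n1`, differs from compound 2 by methyl in place of hydrogen on a saturated chain carbon bound to a nitrogen on an aromatic ring and a saturated chain carbon. Among the compounds with values here, no measured step touches this part of the molecule: the single step known so far concerns configuration only, so it gives no guide to how large a move this change should bring. Without such a guide, the expectation for compound 3 is a step of about a 1.1-fold higher number from compound 2 to compound 3 (0.05 log units; within the scatter), one that stays within the scatter, in either direction. In this assay compound 3 is therefore estimated at 3000 nM, with a range from 1000 nM to 9000 nM.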

Compound 3, half-maximal inhibitory concentration: 2000 nM
Compound 3: middle estimate off by 1.5-fold (0.18 log units), on the high side; low and high end bracket the measured number.
By their numbers in this assay, from the lowest: compounds 3 and 2 (each within the scatter of the next); then compound 1.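

Replacing ethylamino with isopropylamino, which places methyl in place of hydrogen on a saturated chain carbon bound to a nitrogen on an aromatic ring and a saturated chain carbon, gives a 1.3-fold lower number from compound 2 to compound 3 (0.13 log units; within the scatter) in this assay and leaves the two compounds indistinguishable there. This is the first measured step at this part of the molecule, so the added methyl is accepted here, at least with the configuration drawn in compound 2, whereas the change in configuration gave an 11-fold lower number from compound 1 to compound 2 (1.06 log units; beyond the scatter) and remains the only large step among the compounds shown. Nothing measured here offers a reason for the result at this position.

As far as these compounds go, whether a longer chain such as butyl or a bulkier tert-butyl group would be accepted at this position remains open. From the compounds shown here alone, it is also open whether isopropylamino would read the same with the configuration drawn in compound 1.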